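The compounds below may be only part of what the source reports. "The series", "measured", "known", "first", "only" and "open" are said of these compounds alone.

Compound 1 `CC(=O)Nc1ccc(OCc2nnc(SCC(=O)Nc3ccc(Cl)cc3)n2Cc2ccccc2)cc1` gives 14 ug/mL in a toxicity assay on MT4 cells (Homo sapiens) for cytotoxicity, read by MTT assay, with a stated time of 5 days; a higher number here means that more compound is tolerated, a lower number that less compound is tolerated. Compound 2 `CC(=O)Nc1ccc(OCc2nnc(SCC(=O)Nc3ccc(Br)cc3)n2Cc2ccccc2)cc1` gives only a limit in this assay, >= 3.99 ug/mL. Compound 3 `O=C(CSc1nnc(COc2ccc3ccccc3c2)n1Cc1ccccc1)Nc1ccc(Cl)cc1` gives only a limit in this assay, >= 4.93 ug/mL.

Compound 4 `O=C(CSc1nnc(COc2ccc3ccccc3c2)n1Cc1ccccc1)Nc1ccc(Br)cc1` has not been measured. It differs from compound 3 by bromo in place of chloro on an aromatic carbon. The same change has already been made once: compound 2 differs from compound 1 by bromo in place of chloro on an aromatic carbon. The size of that earlier step, a step that the limit leaves unreadable from compound 1 to compound 2, cannot be read because compound 2 sits at the limit of >= 3.99 ug/mL in this assay, at which 1 of the 3 values shown sits. The two cores differ as well: compound 3 differs from compound 1 by naphthalen-2-yl in place of 4-acetamidophenyl on an oxygen on a saturated carbon, and that step, a step that the limit leaves unreadable from compound 1 to compound 3, cannot be read because compound 3 sits at the limit of >= 4.93 ug/mL in this assay, at which 1 of the 3 values shown sits. For compound 4 the step that the limit leaves unreadable from compound 3 to compound 4 is expected to be small. Compound 4 is expected to give about 7 ug/mL in this assay, likely between 3.5 ug/mL and 18 ug/mL, with a fair chance that only a limit is reported again.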

Compound 4, half-maximal cytotoxic concentration: 58.1 ug/mL
Beside the measured number, compound 4's estimate is 8.3-fold (0.92 log units) below it; measured number above the stated range.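

Compound 2 and compound 3 are known only as limits in this assay, and the steps from each of them to compound 4 cannot be read. Going by these compounds, whether bromo in place of chloro changes the tolerated concentration on either core stays open.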